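The compounds below may be only part of what the source reports. "The series", "measured", "known", "first", "only" and "open" are said of these compounds alone.

Measured so far in a functional assay on MCF7 cells (Homo sapiens) for antiproliferative activity, read by MTT assay; on this read-out higher numbers stand for weaker inhibition and lower numbers for stronger inhibition:

compound 1 `NS(=O)(=O)c1ccc(Nc2ncc(/N=C/c3cccs3)c(NC3CCCC3)n2)cc1`, 23000 nM
compound 2 `NS(=O)(=O)c1ccc(Nc2ncc(/N=C/c3ccc(C(F)(F)F)cc3)c(NC3CCCC3)n2)cc1`, which in this assay reaches only the limit > 100000 nM and no number
compound 3 `CC(C)Nc1nc(Nc2ccc(S(N)(=O)=O)cc2)ncc1/N=C/c1cccs1`, 50200 nM

Compound 2 differs from compound 1 by 4-(trifluoromethyl)phenyl in place of thiophen-2-yl on a carbon with a double bond to nitrogen. That change gave an at least 4.3-fold higher number from compound 1 to compound 2 (0.63 log units; beyond the scatter); the size is bounded by the limit of > 100000 nM in this assay, at which 1 of the 3 values shown sits. The cores of compound 3 and compound 1 differ by isopropyl in place of cyclopentyl on a nitrogen on an aromatic ring, with a 2.2-fold higher number from compound 1 to compound 3 (0.34 log units; beyond the scatter).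

Compound 4 `CC(C)Nc1nc(Nc2ccc(S(N)(=O)=O)cc2)ncc1/N=C/c1ccc(C(F)(F)F)cc1` is not yet measured. It differs from compound 3 by 4-(trifluoromethyl)phenyl in place of thiophen-2-yl on a carbon with a double bond to nitrogen, the same change as from compound 1 to compound 2. Compound 3 already shows the higher number 50200 nM. The step is expected to be a 4.4-fold higher number from compound 3 to compound 4 (0.64 log units; beyond the scatter), resting on an at least 4.3-fold higher number from compound 1 to compound 2 (0.63 log units; beyond the scatter), which most likely carries compound 4 beyond what this assay can resolve as a number. The estimate for compound 4 is 220000 nM, within 80000 nM to 600000 nM.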

Compound 4, half-maximal inhibitory concentration: > 100000 nM
Compound 4: a limit, no number (the forecaster's own chance of this, stated with the estimate: 85%); the middle value lies beyond the limit too.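

In this assay compound 4 gives > 100000 nM, which is a limit and not a number. Carried to the core of compound 3, 4-(trifluoromethyl)phenyl in place of thiophen-2-yl gives an at least 1.9-fold higher number from compound 3 to compound 4 (0.29 log units; that floor lies within the scatter), so the result is compatible with the earlier step, but it does not show that the change has the same size on both cores: the same change on two cores in this assay, an at least 4.3-fold higher number (0.63 log units; beyond the scatter) from compound 1 to compound 2 and an at least 1.9-fold higher number (0.29 log units; that floor lies within the scatter) from compound 3 to compound 4; the limit leaves it open whether they differ. The step from compound 2 to compound 4 cannot be read, and the ceiling of the assay limits the series here: the limit of > 100000 nM in this assay, at which 2 of the 4 values shown sit.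

Still open, on these data alone, is how far the numbers actually rise with 4-(trifluoromethyl)phenyl on either core. Also open, as far as these compounds go, is whether a phenyl bearing an amine or a carboxylic acid, on a carbon with a double bond to nitrogen, would give a measurable number.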